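Swapping a pyridyl amide chain for a fluoromethoxyphenyl group

The source may hold more compounds than are shown below. What is called first, only, known or untested is meant among the compounds shown, and "the series" means these compounds.

Measured compounds:
- compound 1, `Cc1cc(C)cc(S(=O)(=O)c2c(C(=O)NCc3cccc(N)c3)[nH]c3ccc(Cl)cc23)c1`: > 53400 nM
- compound 2, `Cc1cc(C)cc(S(=O)(=O)c2c(C(=O)NC(C)C(=O)NCc3ccncc3)[nH]c3ccc(Cl)cc23)c1`: 19500 nM
- compound 3, `Cc1cc(C)cc(S(=O)(=O)c2c(C(=O)NCC(=O)NC(C)c3ccncc3)[nH]c3ccc(Cl)cc23)c1`: 47000 nM

These three compounds share one core and differ only in the group attached to the amide nitrogen. In an ADME assay on MT4 cells (Homo sapiens) for cytotoxicity, read by MTT assay (a higher number here means that more compound is tolerated, a lower number that less compound is tolerated), compound 3 gives 47000 nM, the higher of the two real numbers shown; compound 2 sits a 2.4-fold higher number from compound 2 to compound 3 (0.38 log units; beyond the scatter) away. For compound 1 the result is a limit of the assay, not a number: the limit of > 53400 nM in this assay, at which 1 of the 3 values shown sits. The step of an at least 1.1-fold lower number from compound 1 to compound 3 (0.05 log units; that floor lies within the scatter) therefore has a floor within the scatter, while an at least 2.7-fold lower number from compound 1 to compound 2 (0.43 log units; beyond the scatter) is at least modest.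

Compound 4, `COc1cccc(F)c1CNC(=O)c1[nH]c2ccc(Cl)cc2c1S(=O)(=O)c1cc(C)cc(C)c1`, has not yet been measured. It differs from compound 3 as follows: 2-fluoro-6-methoxyphenyl in place of (1-(pyridin-4-yl)ethyl)carbamoyl on a saturated chain carbon bound to an amide-type nitrogen. Like compound 1, compound 4 carries an aromatic ring directly on the chain carbon rather than a longer amide chain. The step from compound 1 to compound 3 was small, and compound 1 reached only a limit, so no step beyond the scatter is expected in this assay; compound 4 is estimated at 50000 nM, between 20000 nM and 110000 nM, with the expected step of a 1.1-fold higher number from compound 3 to compound 4 (0.03 log units; within the scatter).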

Compound 4, half-maximal cytotoxic concentration: > 49900 nM
Compound 4: no number, only a limit; the forecaster's own chance of this, stated with the estimate: 50%; the middle value lies beyond the limit too.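

In this assay compound 4 gives a limit of the assay, not a number: the limit of > 49900 nM in this assay, at which 1 of the 4 values shown sits. Placing 2-fluoro-6-methoxyphenyl on the saturated chain carbon bound to an amide-type nitrogen gives an at least 1.0-fold higher number from compound 3 to compound 4 (0.02 log units; that floor lies within the scatter), so no change from the pyridyl amide chain can be claimed on that floor, while the other pyridyl amide chain shows an at least 2.5-fold higher number from compound 2 to compound 4 (0.40 log units; beyond the scatter). This adds a ring of carbon only, without the amine of the ring in the first compound, to the groups that give no sign of lower tolerance here, and the step involving compound 1 cannot be read: the limit of > 53400 nM in this assay, at which 1 of the 4 values shown sits.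

Going by these compounds, how much of compound 1 or compound 4 cells would tolerate stays unknown, so their two aromatic groups cannot be ranked. On these data alone, whether a carboxylic acid on that ring, or a longer chain leading to it, would lower the number also stays open.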